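Allyl Substitution on the Core of Compound 2

The source may report more compounds than this note shows. Statements on the series, on what has been measured and on what is new or still open speak of the compounds shown alone.

The series was studied in a functional assay on aorta (Rattus norvegicus, strain Sprague-Dawley) for inhibition, with a stated time of 20 min; on this read-out higher numbers stand for larger maximal responses and lower numbers for smaller maximal responses. Compound 1 `C=CCc1cc(O)cc(C(=O)/C=C/c2ccc(O)cc2)c1O` gives 59.8% in this assay. Compound 2 `O=C1CC(c2cccc(Br)c2)Oc2cc(O)cc(O)c21` gives 93.5%, and compound 3 `O=C1CC(c2cccc(Br)c2)Oc2ccc(O)cc21` gives 91.8%. Compound 2 stands at the top of the three numbers, but compound 3 lies within the usual scatter of it, so the two cannot be told apart; compound 1 lies well below both, beyond the scatter.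

Compound 4 `C=CCc1c(O)cc(O)c2c1OC(c1cccc(Br)c1)CC2=O` has not been measured. It differs from compound 2 by allyl in place of hydrogen on an aromatic carbon. Among the measured compounds shown here, no pair of measured compounds differs only in this way, so the size of the step is not known from the data. Compound 1 also carries an allyl group and sits lowest, but it differs from compound 2 in many further places, so its value is no guide to this single change.

The author expects a moderate step downward, near the edge of the scatter, so that the step from compound 2 to compound 4 in this assay is about a number 11.5 percentage points lower from compound 2 to compound 4 (beyond the scatter). Compound 4 is estimated at 82%, within a range from 60% to 98%.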

Compound 4, largest response reached (Emax), in percent of the reference or control that the assay uses: 78.8%
For compound 4 the middle estimate is 3.2 percentage points above the measured one; the range from low to high includes it.
By their numbers in this assay, from the lowest: compound 1; then compound 4; then compounds 3 and 2 (each within the scatter of the next).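

In this assay, the aromatic carbon ortho to a hydroxy group and para to a hydroxy group is shown to respond to substitution: allyl in place of hydrogen gives a number 14.7 percentage points lower from compound 2 to compound 4 (beyond the scatter). Among the compounds shown here, this is the first change at a single place that can be read, and although modest, the step lies beyond the scatter, so the change at this carbon alone is enough to lower the maximal response. Nothing in the data shown explains the step.

Going by these compounds, whether the step belongs to allyl in particular remains open, as a methyl group or a longer chain such as prenyl on the same carbon might give a step of a different size. On these data alone, the outcome with an amine or a carboxylic acid at this place also remains open.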